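This account rests on a few compounds, and the source may have more. Where it says the series, first, only, none or still open, it means among the compounds named here.

Compound 1 `ClCc1ccc(Cn2cnc3c(Cl)ncnc32)cc1`: > 100000 nM
Compound 2 `ClCc1ccccc1Cn1cnc2c(Cl)ncnc21`: 7240 nM
Compound 3 `ClCc1cccc(Cn2cnc3c(Cl)ncnc32)c1`: 66100 nM

These three compounds were tested in a functional assay on NCI-H522 cells (Homo sapiens) for cytotoxicity, read by sulforhodamine B assay, with a stated time of 48 h; a higher number here means a weaker inhibitor of growth, a lower number a stronger inhibitor of growth. For compound 1 the value is a limit of the assay and not a number, as noted in the limit of > 100000 nM in this assay, at which 1 of the 3 values shown sits. Among the two numbers, compound 3 stands highest; its nearest neighbour is compound 2, whose number is lower by a margin beyond the scatter. Compound 4 `ClCc1cccc(Cn2cnc3c(Cl)nc(Cl)nc32)c1` has not yet been measured. It differs from compound 3 in one place: chloro in place of hydrogen on an aromatic carbon, on the shared core. Going by the values given here, no measured pair among the three compounds shows a change of this kind, so there is no step on which to base the size or direction of the effect. Without such a comparison, the step from compound 3 to compound 4 in this assay is expected to stay close to none beyond the scatter, put at a 1.2-fold lower number from compound 3 to compound 4 (0.08 log units; within the scatter). Compound 4 is therefore estimated at 55000 nM, with a range from 15000 nM to 100000 nM.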

Compound 4, concentration for total growth inhibition: 5370 nM
For compound 4 the middle estimate is 10-fold (1.01 log units) above the measured one; measured number outside the range, below it.
By their numbers in this assay, from the lowest: compounds 4 and 2 (each within the scatter of the next); then compound 3. At a limit, above all of these: compound 1.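

The change of chloro in place of hydrogen on an aromatic carbon of the shared core gives a 12-fold lower number from compound 3 to compound 4 (1.09 log units; beyond the scatter) in this assay and is the first change to the core itself among the compounds shown. It shows that this position, on the six-membered aromatic ring with 2 nitrogen and between two ring nitrogen atoms, responds strongly to substitution: one chlorine atom moves the number towards stronger inhibition of growth. Nothing measured here accounts for the size of this step.

Going by these compounds, it remains open whether this step belongs to chloro itself or would also follow from another group at this place, such as an amine, a methoxy group or a fluoro group. On these data alone, it is also open whether chloro gives a similar step on the core of compound 2 or of compound 1.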